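The source may report more compounds than this note shows. Statements on the series, on what has been measured and on what is new or still open speak of the compounds shown alone.

Measured so far:
- compound 1 `COc1ccc(/C=C2\CCC/C(=C\c3ccc(OC)c(OC)c3)C2=O)cc1` gives > 20000 nM
- compound 2 `COc1ccc(/C=C2\CCC/C(=C\c3cccc(Cl)c3Cl)C2=O)cc1OC` gives > 20000 nM

Both entries are limits and not numbers. In a functional assay on A549 cells (Homo sapiens) for cytotoxicity, read by MTT assay, with a stated time of 72 h (on this read-out higher numbers stand for weaker inhibition and lower numbers for stronger inhibition), compound 2 stands only at a limit of > 20000 nM and has no measured number of its own. Compound 1 is at a limit as well, so the two compounds cannot be ranked.

Compound 3 `COc1ccc(/C=C2\CCC/C(=C\c3ccc(Cl)c(Cl)c3)C2=O)cc1OC` carries 3,4-dichlorophenyl in place of 2,3-dichlorophenyl on a double-bonded chain carbon bound to a double-bonded ring carbon, a change counted as 3,4-dichlorophenyl in place of 2,3-dichlorophenyl on a double-bonded chain carbon bound to a double-bonded ring carbon and one in which the same atoms are joined differently.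

Among the measured compounds shown here, only one measured step bears on this, and it gives no size: a step that the two limits leave unreadable from compound 1 to compound 2 is the whole of it. Beyond that step there is only the limit of > 20000 nM in this assay, at which 2 of the 2 values shown sit, to go on. For the measured compounds named here, no measured compound therefore shows how much the dichlorophenyl pattern matters, and no step beyond the scatter is expected in this assay, in either direction. The step expected is a number no higher from compound 2 to compound 3 (the limit leaves the size open) and another limit is quite likely.

The estimate for compound 3 is 20000 nM, with an expected range from 7000 nM to 40000 nM in this assay.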

Compound 3, half-maximal inhibitory concentration: 6900 nM
The estimate for compound 3 lay 2.9-fold (0.46 log units) above the measured number; the whole stated range lies above it.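

In this assay, 3,4-dichlorophenyl in place of 2,3-dichlorophenyl on a double-bonded chain carbon bound to a double-bonded ring carbon gives an at least 2.8-fold lower number from compound 2 to compound 3 (0.46 log units; beyond the scatter), so the read-out at this place responds to how the two chlorines are arranged, even though no atom is gained or lost. Set against 4-methoxyphenyl at the same place, 3,4-dichlorophenyl gives an at least 2.8-fold lower number from compound 1 to compound 3 (0.46 log units; beyond the scatter), whereas the step between 4-methoxyphenyl and 2,3-dichlorophenyl cannot be read. Compound 3 is the first compound here with a number of its own, and both step sizes are only minimums, as the other two compounds stand at a limit: the limit of > 20000 nM in this assay, at which 2 of the 3 values shown sit.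

The compounds shown leave open how far apart compound 1 and compound 2 really lie, and whether a single chlorine, as in 4-chlorophenyl or 3-chlorophenyl, would give a number like that of compound 3. They also leave open what other groups at this place would do, such as a pyridine ring or a phenyl ring carrying an amine or a carboxylic acid.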